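The compounds below may be only part of what the source reports. "The series", "measured", "known", "first", "only" and "open" are said of these compounds alone.

Values in a functional assay on DU-145 cells (Homo sapiens) for inhibition (a higher number here means a weaker inhibitor, a lower number a stronger inhibitor), so far:
compound 1 `COc1ccc(Cl)cc1-c1cc(Nc2ccc(Cl)cc2)nc(N)n1` gives 500 nM
compound 2 `CCOc1ccc(Br)cc1-c1cc(Nc2ccc(C(=O)NO)cc2)nc(N)n1` gives > 1000 nM (a limit)
compound 3 `CCOc1ccc(Cl)cc1-c1cc(Nc2cccc([N+](=O)[O-])c2)nc(N)n1` gives > 1000 nM (a limit)

Compound 2 has no number in this assay, only the limit > 1000 nM as its reading. Compound 3 has a limit as well, so the evidence so far is the limit of > 1000 nM in this assay, at which 2 of the 3 values shown sit, and nothing finer. Only compound 1 gives a number, 500 nM as its reading, and it differs from compound 2 in more than one place.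

The next compound to be read is compound 4 `CCOc1ccc(Br)cc1-c1cc(Nc2ccccc2)nc(N)n1`. Its change from compound 2 is hydrogen in place of hydroxycarbamoyl on an aromatic carbon, para to a large group.

Among the compounds with values here, no measured pair shows this change on its own, so the expectation is loose. In this assay a small step towards stronger inhibition is expected, possibly none beyond the scatter, and another limit reading is about as likely as a number. The expected step, an estimate only, is a number no higher from compound 2 to compound 4 (the limit leaves the size open) in size. For compound 4 the estimated value is 1000 nM, with an expected range from 350 nM to 3000 nM in this assay.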

Compound 4, half-maximal inhibitory concentration: > 1000 nM
Compound 4 gave a limit, no number (the forecaster's own chance of this, stated with the estimate: 50%); the middle value lies on the limit itself.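

In this assay compound 2 reads > 1000 nM, a limit. Compound 4 reads > 1000 nM, also a limit, so no step can be read between compound 2 and compound 4. The compounds shown leave open what hydrogen in place of hydroxycarbamoyl on an aromatic carbon does to inhibition, and the evidence stays at one reading: the limit of > 1000 nM in this assay, at which 3 of the 4 values shown sit.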